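Removing the tetrazolyl-benzyl arm: what the phenol may show

This account rests on a few compounds, and the source may have more. Where it says the series, first, only, none or still open, it means among the compounds named here.

Compound 1, `O=C(NCc1ccc(OCc2ccccc2)cc1)[C@@H]1CCC(=O)N1Cc1ccccc1`, in an assay on HEK293 cells for inhibition of Ataxin-2 (Mus musculus), read by fluorescence and Amplex Red; a higher number here means a weaker inhibitor, a lower number a stronger inhibitor: > 5000 nM (a limit of the assay)
Compound 2, `O=C(NCc1ccccc1)[C@@H]1CCC(=O)N1Cc1ccccc1`, in this assay: > 5000 nM (a limit of the assay)
Compound 3, `O=C(NCc1ccc(OCc2ccc(-c3nn[nH]n3)cc2)cc1)[C@@H]1CCC(=O)N1Cc1ccccc1`, in this assay: > 5000 nM (a limit of the assay)

Compound 3 stands only at a limit: in this assay compound 3 gives > 5000 nM, which is a limit of the assay and not a number. The same holds for the two other measured compounds, so that the limit of > 5000 nM in this assay, at which 3 of the 3 values shown sit, describes the whole set.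

Compound 4, `O=C(NCc1ccc(O)cc1)[C@@H]1CCC(=O)N1Cc1ccccc1`, has not yet been measured. It differs from compound 3 in one place: hydrogen in place of 4-(2H-tetrazol-5-yl)benzyl on an oxygen on an aromatic ring. The oxygen on the aromatic ring thus carries only a hydrogen, and the large arm is gone.

Going by the values given here, two measured steps touch the same region. The step that the two limits leave unreadable from compound 1 to compound 2 and the step that the two limits leave unreadable from compound 1 to compound 3 both start and end at the limit, so neither gives a readable size or direction. Nothing measured therefore says whether cutting back the arm helps or harms.

The expectation rests on this: since every measured compound sits at the limit, compound 4 is estimated to remain there as well, with a value of 8000 nM and a range from 2000 nM to 50000 nM. The step this estimate means, a step that the limit leaves unreadable from compound 3 to compound 4, is expected to be no change beyond the scatter.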

Compound 4, half-maximal inhibitory concentration: > 5000 nM
Compound 4: only a limit was reported; the forecaster's own chance of this, stated with the estimate: 85%; the middle value is on the limit's open side.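

In this assay compound 4 gives > 5000 nM as a limit of the assay, not a number. Compound 1, compound 2 and compound 3 also stand at a limit, so no step among these compounds can be read: the limit of > 5000 nM in this assay, at which 4 of the 4 values shown sit. Still open, going by these compounds, is whether any change to the arm on the oxygen moves the value, and in which direction.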